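Swapping a Benzyl Arm for a Hydroxyethyl Chain

The compounds below may be only part of what the source reports. "The series", "measured", "known", "first", "only" and "open" are said of these compounds alone.

Compound 1 `C/C(=N\Cc1ccccc1)c1c(O)c2ccccc2[nH]c1=O` carries a benzyl group on the saturated chain carbon bound to a double-bonded nitrogen. In an assay on isolated protein for inhibition of myosin-2 (Bos taurus), read by spectrophotometry, with a stated time of 24 min (on this read-out lower numbers stand for stronger inhibition and higher numbers for weaker inhibition), compound 1 gives only a limit of the measurement, >= 100000 nM, so its true strength is not pinned to a number. Two related compounds share a different core: compound 2 `C/C(=N\Cc1cccc(C)c1)c1c(O)c2ccccc2oc1=O` gives 4900 nM in this assay, and compound 3 `C/C(=N\Cc1cccnc1)c1c(O)c2ccccc2oc1=O` gives 17000 nM. For the measured compounds named here, the one step between them, a 3.5-fold higher number from compound 2 to compound 3 (0.54 log units; beyond the scatter), exchanges one six-membered aromatic ring for another and is the only measured comparison available here.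

Compound 4 `C/C(=N\CCO)c1c(O)c2ccccc2[nH]c1=O` differs from compound 1 in that (hydroxymethyl in place of phenyl on a saturated chain carbon bound to a double-bonded nitrogen). Going by the values given here, no measured step trades an aromatic ring for a short hydroxyl-bearing chain on this core, and the step from compound 2 to compound 3 is only a loose guide, since it keeps a ring in place. Since compound 1 already stands at the limit (the limit of >= 100000 nM in this assay, at which 1 of the 3 values shown sits), compound 4 is expected to reach or stay near that limit as well. The expected step, a number no higher from compound 1 to compound 4 (the limit leaves the size open), amounts to no movement beyond the scatter. Compound 4 is therefore estimated at 100000 nM, within a range from 30000 nM to 300000 nM.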

Compound 4, half-maximal inhibitory concentration: >= 100000 nM
Compound 4: only a limit was reported (the forecaster's own chance of this, stated with the estimate: 70%); the middle value lies on the limit itself.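

For the compounds shown here, compound 1 and compound 4 both stop at a limit of the measurement rather than at a number, so no step between them can be read: the limit of >= 100000 nM in this assay, at which 2 of the 4 values shown sit. Going by these compounds, what stays open is how strongly either compound inhibits in this assay and whether benzyl and 2-hydroxyethyl differ at all on their shared core.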